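From cyanomethyl to 2-cyanoethyl on compound 3

The source may report more compounds than this note shows. Statements on the series, on what has been measured and on what is new or still open speak of the compounds shown alone.

Measured in a functional assay on U-87MG ATCC cells for cytotoxicity against U-87 MG (Homo sapiens), read by colorimetric assay and MTT assay; a lower number here means a stronger inhibitor, a higher number a weaker inhibitor:
compound 1 `COc1cccc2cc(-c3ccccc3)c(O)nc12`: 10000 nM
compound 2 `COc1cc(OC)c2cc(-c3ccc(OCc4ccccc4)cc3)c(O)nc2c1`: 10000 nM
compound 3 `COc1ccc(-c2cc3c(OC)cc(OC)cc3n(CC#N)c2=O)cc1`: 10000 nM

Level with compound 1 and compound 2, compound 3 stands at 10000 nM, so no difference among the three can be read. The next compound, compound 4 `COc1ccc(-c2cc3c(OC)cc(OC)cc3n(CCC#N)c2=O)cc1`, changes one place: cyanomethyl in place of cyano on a saturated chain carbon bound to an aromatic nitrogen. Within the data shown here, no measured pair here isolates a single change, so the data offer no step size to lean on. With compound 3 at 10000 nM, a change this small is expected to give no step beyond the scatter in this assay, in either direction. The expected no change at the digits printed from compound 3 to compound 4 (within the scatter) therefore stays within that scatter. For compound 4 the estimate is 10000 nM, with an expected range of 5000 nM to 20000 nM.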

Compound 4, half-maximal inhibitory concentration: 10000 nM
The estimate for compound 4 equals the measured number at the digits printed; measured number inside the range.
By their numbers in this assay, from the lowest: compounds 1, 2, 3 and 4 (each within the scatter of the next).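

Going from cyanomethyl to 2-cyanoethyl on a saturated chain carbon bound to an aromatic nitrogen gives no change at the digits printed from compound 3 to compound 4 (within the scatter) in this assay and so provides the first pair here that differs in one place. It shows that this small lengthening of the chain leaves the reading unmoved. Nothing measured here offers an explanation for this result. Still open, from the compounds shown here alone, is whether an amine, a carboxylic acid or a much longer chain at this place would move the number. With all four compounds reading alike, no change yet shown does so.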